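This account rests on a few compounds, and the source may have more. Where it says the series, first, only, none or still open, it means among the compounds named here.

Series notes, maximal response in a functional assay on the whole organism (B cells) with Mus musculus as the target; on this read-out lower numbers stand for smaller maximal responses and higher numbers for larger maximal responses:

- compound 1 `C=CCn1c(=O)n([C@H]2CO[C@@H](CO)C2)c2nc(N)nc(O)c21`: 10%
- compound 2 `C=CCn1c(=O)n(C2C=CC(CO)O2)c2nc(N)nc(O)c21`: 45%
- compound 3 `C=CCn1c(=O)n(Cc2ccccc2)c2nc(N)nc(O)c21`: 25%

Compound 3 stands second highest of the three numbers in this assay: compound 1 sits lower by a number 15 percentage points higher from compound 1 to compound 3 (beyond the scatter), and compound 2 sits higher by a number 20 percentage points lower from compound 2 to compound 3 (beyond the scatter). All three compounds share one core and differ only in the group on the aromatic nitrogen.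

Compound 4 `C=CCn1c(=O)n(CCCCO)c2nc(N)nc(O)c21` continues from compound 3 with 3-hydroxypropyl in place of phenyl on a saturated chain carbon bound to an aromatic nitrogen. Going by the values given here, the two measured steps that bear on this position, a number 15 percentage points higher from compound 1 to compound 3 (beyond the scatter) and a number 20 percentage points lower from compound 2 to compound 3 (beyond the scatter), both exchange one ring for another; no measured step replaces a ring with an open chain. Both steps are modest, and the two compounds carrying a hydroxymethyl group, compound 1 and compound 2, sit on either side of compound 3. An open chain ending in a hydroxyl is therefore expected to move the maximal response in this assay by no more than a modest step, with the direction uncertain; a small downward shift is expected, a number 5 percentage points lower from compound 3 to compound 4 (within the scatter).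

The expected value for compound 4 is 20%, estimated within 8% to 45%.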

Compound 4, largest response reached (reported as maximal response), in percent of the reference or control that the assay uses: 12%
Compound 4: the middle estimate sits 8 percentage points above what was measured; the range from low to high includes it.
By their numbers in this assay, from the lowest: compounds 1 and 4 (each within the scatter of the next); then compound 3; then compound 2.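

In this assay, the first open chain at this position gives a number 13 percentage points lower from compound 3 to compound 4 (beyond the scatter) on going from benzyl to 4-hydroxybutyl, so the change from an aromatic ring to a chain ending in a hydroxyl lowers the response rather than leaving it in place. The chain and the ring-bearing group with its hydroxymethyl read alike, with a number 2 percentage points higher from compound 1 to compound 4 (within the scatter) as the printed step, so a ring at this position is not required for a number at this low level. The open chain stays well short of the top of the series, as a number 33 percentage points lower from compound 2 to compound 4 (beyond the scatter) shows, and compound 2 also carries a hydroxymethyl, so a hydroxyl alone does not fix the number.

No evidence on the cause of these steps is available. Going by these compounds, whether the hydroxyl or the chain itself sets the number remains open, and a plain butyl, a chain ending in an amine or a carboxylic acid, or a longer chain would be needed to separate the two.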